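The source may hold more compounds than are shown below. What is called first, only, known or untested is meant among the compounds shown, and "the series" means these compounds.

Of the compounds shown here, three sharing one core have been tested in a functional assay on NCI-H460 cells (Homo sapiens) for cytotoxicity, read by MTT assay; a lower number here means a stronger inhibitor, a higher number a weaker inhibitor. Compound 1 `CCc1cc(S(=O)(=O)N2C[C@H](c3ccccc3)NC2=O)ccc1NC(=O)OC` gives 300 nM, compound 2 `CCc1cc(S(=O)(=O)N2C[C@H](c3ccccc3)NC2=O)ccc1NC(=O)NC1CCCCC1` gives 300 nM, and compound 3 `CCc1cc(S(=O)(=O)N2C[C@H](c3ccccc3)NC2=O)ccc1NC(=O)NC(C)C` gives 70 nM, the lowest of the three numbers. The steps of a 4.3-fold lower number from compound 1 to compound 3 (0.63 log units; beyond the scatter) and a 4.3-fold lower number from compound 2 to compound 3 (0.63 log units; beyond the scatter) each alter the group on the carbonyl carbon and were modest, whereas no change at the digits printed from compound 1 to compound 2 (within the scatter). Compound 4 `CCc1cc(S(=O)(=O)N2C[C@H](c3ccccc3)NC2=O)ccc1NC(=O)c1ccc(N)cc1` differs from compound 3 in that (4-aminophenyl in place of isopropylamino on a carbonyl carbon). Among the compounds with values here, no measured compound carries an aromatic ring at that place, so the direction is uncertain, and the measured steps point to a modest change at most. Compound 4 is therefore expected to give about 200 nM in this assay, within a range of 50 nM to 800 nM. This estimate corresponds to an expected step of a 2.9-fold higher number from compound 3 to compound 4 (0.46 log units; beyond the scatter).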

Compound 4, half-maximal inhibitory concentration: 670 nM
For compound 4 the middle estimate is 3.4-fold (0.53 log units) below the measured one, within the range that was stated.
By their numbers in this assay, from the lowest: compound 3; then compounds 1 and 2 (each within the scatter of the next); then compound 4.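

In this assay, 4-aminophenyl, the first aromatic ring measured on this carbonyl carbon, gives the largest step in the series (a 9.6-fold higher number from compound 3 to compound 4 (0.98 log units; beyond the scatter)). Compound 4 also has a higher number than the two compounds that share the next position (a 2.2-fold higher number from compound 2 to compound 4 (0.35 log units; beyond the scatter); a 2.2-fold higher number from compound 1 to compound 4 (0.35 log units; beyond the scatter)), so this change gives the highest number of the four. No evidence here explains the result.

Going by these compounds, whether the ring alone or its amino group drives the step remains open. A plain phenyl or a 4-hydroxyphenyl group at this place would help separate the two.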